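Aryl Swap on Two Related Cores: Expectation for Compound 4

This account rests on a few compounds, and the source may have more. Where it says the series, first, only, none or still open, it means among the compounds named here.

Of the compounds shown here, three have been measured in a functional assay on HCT-116 cells (Homo sapiens) for inhibition, read by sulforhodamine B assay, with a stated time of 72 h; a lower number here means a stronger inhibitor, a higher number a weaker inhibitor. Compound 1 `COc1ccc2cc(C(C)c3nnc4n3N=C(c3ccc(Br)cc3)CS4)ccc2c1` gives 11700 nM, compound 2 `COc1ccc2cc(C(C)c3nnc4n3N=C(c3ccc(Cl)cc3Cl)CS4)ccc2c1` gives 14000 nM, and compound 3 `CC(C)Cc1ccc(C(C)c2nnc3n2N=C(c2ccc(Cl)cc2Cl)CS3)cc1` gives 11100 nM; all three numbers lie within the scatter of one another. Compound 1 differs from compound 2 by 4-bromophenyl in place of 2,4-dichlorophenyl on a carbon with a double bond to nitrogen, and in this assay this change made a step of a 1.2-fold lower number from compound 2 to compound 1 (0.08 log units; within the scatter). How the core of compound 3 differs from the core of compound 2 is not broken down here. Compound 4 `CC(C)Cc1ccc(C(C)c2nnc3n2N=C(c2ccc(Br)cc2)CS3)cc1` is not yet measured; it differs from compound 3 by 4-bromophenyl in place of 2,4-dichlorophenyl on a carbon with a double bond to nitrogen, the same change at the same place as between compound 2 and compound 1. Because compound 3 gives 11100 nM and the earlier change gave a 1.2-fold lower number from compound 2 to compound 1 (0.08 log units; within the scatter), compound 4 is expected to show a step of a 1.2-fold lower number from compound 3 to compound 4 (0.07 log units; within the scatter) in this assay. Compound 4 is therefore estimated at 9500 nM in this assay, expected to fall between 5000 nM and 20000 nM.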

Compound 4, half-maximal inhibitory concentration: 7100 nM
Compound 4: middle estimate off by 1.3-fold (0.13 log units), on the high side; measured number inside the range.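

Carried to the second core, 4-bromophenyl in place of 2,4-dichlorophenyl gave a 1.6-fold lower number from compound 3 to compound 4 (0.19 log units; within the scatter) in this assay. Set beside the earlier step, the new one shows no difference between the two cores: the same change on two cores in this assay, a 1.2-fold lower number (0.08 log units; within the scatter) from compound 2 to compound 1 and a 1.6-fold lower number (0.19 log units; within the scatter) from compound 3 to compound 4, 1.3-fold (0.12 log units) apart, within the scatter of two such steps. Among these compounds, this agreement is limited, however: both steps lie within the scatter, so the pair shows only that the change stayed small on these two cores, not that it has a real effect of its own or that it would carry over to further cores.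

The compounds shown leave open whether a larger step at this place would carry over in the same way. Also open, from the compounds shown here alone, is how either core would respond to an amine or a carboxylic acid in place of the 4-bromophenyl.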